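A few compounds are considered here, and "the series" means these few. Any claim that something is new, unique, unknown or untested is made for them only; others in the source may bear on it.

The shared core of compound 1 `O=C(/C=C/CN1CCCCC1)Nc1ccccc1` carries an unsaturated chain on the amide. In an ADME assay for pharmacokinetics, read by LC-MS, in phosphate buffer, with a stated time of 120 min, at pH 7.4, tested at 1 uM, in the presence of a further agent that is not named here (on this read-out higher numbers stand for a longer-lived compound and lower numbers for a shorter-lived compound), compound 1 gives 2.95 h, the highest of the two plain numbers in hand. Compound 3 `C=C(Cl)C(=O)Nc1ccccc1` gives 0.05 h in this assay. Compound 2 `C=C(CO)C(=O)Nc1ccccc1` reaches only the limit of this assay, > 8.53 h, which is a limit and not a number (the limit of > 8.53 h in this assay, at which 1 of the 3 values shown sits). Among the compounds with values here, the one step between measured compounds is an at least 170-fold lower number from compound 2 to compound 3 (2.23 log units; beyond the scatter), a large drop that goes with chloro in place of hydroxymethyl on a double-bonded chain carbon bound to a carbonyl carbon.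

Compound 4 `O=C(/C=C/CN1CCCC1)Nc1ccccc1` differs from compound 1 by pyrrolidin-1-yl in place of piperidin-1-yl on a saturated chain carbon bound to a double-bonded chain carbon. Within the data shown here, no measured step touches this part of the molecule: the change from compound 2 to compound 3 sits on the double-bonded chain carbon, whereas here a saturated chain carbon bound to a double-bonded chain carbon bears pyrrolidin-1-yl in place of piperidin-1-yl. With nothing in hand that speaks to the size of this ring, the expectation is a step no larger than the scatter, in neither direction. Compound 4 is therefore estimated to give 2.95 h in this assay, within a range from 1.5 h to 6 h. The expected step is no change at the digits printed from compound 1 to compound 4 (within the scatter).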

Compound 4, half-life: 2.7 h
For compound 4 the middle estimate is 1.1-fold (0.04 log units) above the measured one, within the range that was stated.
By their numbers in this assay, from the lowest: compound 3; then compounds 4 and 1 (each within the scatter of the next). At a limit, above all of these: compound 2.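

In this assay, within the data shown here, the first reading at this place, on a saturated chain carbon bound to a double-bonded chain carbon, is a 1.1-fold lower number from compound 1 to compound 4 (0.04 log units; within the scatter), so piperidin-1-yl and pyrrolidin-1-yl cannot be told apart by half-life here. Among these compounds, the earlier compounds could not show this: their only step, a large one, lay on a double-bonded chain carbon bound to a carbonyl carbon, and it left this saturated chain carbon untouched. Among the compounds shown here, nothing measured so far gives a reason why the two rings read alike.

On these data alone, whether this place stays as undemanding for other groups remains open: an open-chain dimethylamino group, a morpholine ring, a piperazine ring or a carboxylic acid on the same saturated chain carbon could read differently from both rings. The compounds shown also leave open whether chloro or hydroxymethyl on the double-bonded chain carbon would go with a step of the same size in a compound that keeps the piperidin-1-yl chain of compound 1, and whether a longer chain leading to the ring would alter the half-life.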